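Swapping the Azole on the Ring Nitrogen

The source may report more compounds than this note shows. Statements on the series, on what has been measured and on what is new or still open speak of the compounds shown alone.

Compound 3 `CC(C)c1nc(N2CCC(CCCNc3ccc4c(c3)OCC4=O)CC2)no1` carries a 5-isopropyl-1,2,4-oxadiazol-3-yl group on an amine nitrogen in a ring. In a functional assay on CHO-K1 cells for agonist activity at Glucose-dependent insulinotropic receptor (Mus musculus), read by HTRF and cAMP accumulation, with a stated time of 30 min (on this read-out lower numbers stand for an effect already at smaller amounts and higher numbers for an effect only at larger amounts of compound), compound 3 gives "not determined" (no result reported), so no single number places it against the other compounds. Its nearest relatives are compound 1 `CC(C)(C)OC(=O)N1CCC(CCCNc2ccc3c(c2)OCC3=O)CC1` and compound 2 `CCc1cnc(N2CCC(CCCNc3ccc4c(c3)OCC4=O)CC2)nc1`; in this assay compound 1 gives 66 nM, and in the same assay compound 2 gives 159 nM. For the measured compounds named here, the only resolved step between measured compounds, a 2.4-fold higher number from compound 1 to compound 2 (0.38 log units; beyond the scatter), changes the group on the same ring nitrogen that is varied here, and it was modest.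

Compound 4 `CC(C)c1nsc(N2CCC(CCCNc3ccc4c(c3)OCC4=O)CC2)n1` differs from compound 3 only at that position: 3-isopropyl-1,2,4-thiadiazol-5-yl in place of 5-isopropyl-1,2,4-oxadiazol-3-yl on an amine nitrogen in a ring. Going by the values given here, no measured step sets these two azoles against each other, and compound 3 itself brings no number, so the step from compound 3 to compound 4 in this assay cannot be sized from the data; what is counted in the two groups matches closely, and no step beyond the scatter is expected in either direction. Compound 4 is therefore expected to land near the figures of its measured relatives. In this assay compound 4 is estimated at 110 nM, with an expected range from 40 nM to 300 nM.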

Compound 4, half-maximal effective concentration: 812 nM
The estimate for compound 4 lay 7.4-fold (0.87 log units) below the measured number; the measured number lies above the stated range.
By their numbers in this assay, from the lowest: compound 1; then compound 2; then compound 4.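

In this assay, for the compounds shown here, the result shows that the group on this amine nitrogen in a ring can shift the number further than the one earlier step suggested: replacing 5-ethylpyrimidin-2-yl with 3-isopropyl-1,2,4-thiadiazol-5-yl gives a 5.1-fold higher number from compound 2 to compound 4 (0.71 log units; beyond the scatter), and replacing tert-butoxycarbonyl with the same group gives a 12-fold higher number from compound 1 to compound 4 (1.09 log units; beyond the scatter), the latter a large step where the earlier one was modest. Carrying an aromatic ring at this position therefore does not place a compound at one level, since compound 2 and compound 4 both do so and their numbers lie apart beyond the scatter. No measurement shown accounts for the rise from any of these groups to the thiadiazole.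

The steps involving compound 3 cannot be read, so the compounds shown leave open how the 5-isopropyl-1,2,4-oxadiazol-3-yl group compares with its sulfur-containing counterpart on the same nitrogen. They also leave open where an isopropoxycarbonyl group or a 5-chloropyrimidin-2-yl group would fall relative to the tert-butoxycarbonyl and 5-ethylpyrimidin-2-yl groups at this position.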